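The source may report more compounds than this note shows. Statements on the series, on what has been measured and on what is new or still open speak of the compounds shown alone.

In a functional assay on MCF7 cells (Homo sapiens) for cytotoxicity, read by sulforhodamine B assay, with a stated time of 48 h (on this read-out lower numbers stand for stronger inhibition and higher numbers for weaker inhibition), compound 3 `CC(=O)OC[C@H]1O[C@@H](n2cc(CN3C(=O)/C(=C\c4ccc5ccccc5c4)c4ccccc43)nn2)[C@H](OC(C)=O)[C@@H](OC(C)=O)[C@@H]1OC(C)=O` gives 46500 nM, the highest of the three numbers, although the others sit close by: compound 2 `CC(=O)OC[C@H]1O[C@@H](n2cc(CN3C(=O)/C(=C\C=C\c4ccccc4)c4ccccc43)nn2)[C@H](OC(C)=O)[C@@H](OC(C)=O)[C@@H]1OC(C)=O` gives 34100 nM and compound 1 `CC(=O)OC[C@H]1O[C@@H](n2cc(CN3C(=O)/C(=C\c4ccccc4)c4ccccc43)nn2)[C@H](OC(C)=O)[C@@H](OC(C)=O)[C@@H]1OC(C)=O` gives 24300 nM. Every measured step exchanges the group on a double-bonded chain carbon bound to a double-bonded ring carbon, and each stayed small: a 1.4-fold higher number from compound 1 to compound 2 (0.15 log units; within the scatter), a 1.9-fold higher number from compound 1 to compound 3 (0.28 log units; within the scatter) and a 1.4-fold higher number from compound 2 to compound 3 (0.13 log units; within the scatter). Compound 4 `CC(=O)OC[C@H]1O[C@@H](n2cc(CN3C(=O)/C(=C\c4ccco4)c4ccccc43)nn2)[C@H](OC(C)=O)[C@@H](OC(C)=O)[C@@H]1OC(C)=O` makes the same kind of exchange at the same place: furan-2-yl in place of naphthalen-2-yl on a double-bonded chain carbon bound to a double-bonded ring carbon. As the earlier exchanges moved the numbers only within the scatter, for instance a 1.9-fold higher number from compound 1 to compound 3 (0.28 log units; within the scatter), compound 4 is expected to show no step beyond the scatter, roughly a 1.6-fold lower number from compound 3 to compound 4 (0.19 log units; within the scatter). The estimate for compound 4 in this assay is therefore 30000 nM, somewhere between 12000 nM and 75000 nM.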

Compound 4, half-maximal inhibitory concentration: 38200 nM
Compound 4: middle estimate off by 1.3-fold (0.10 log units), on the low side; measured number inside the range.
By their numbers in this assay, from the lowest: compounds 1, 2, 4 and 3 (each within the scatter of the next).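

Furan-2-yl is the first group at this place with a ring oxygen and a hydrogen-bond acceptor, and it has fewer heavy atoms than naphthalen-2-yl, yet the steps stay small: a 1.2-fold lower number from compound 3 to compound 4 (0.09 log units; within the scatter), a 1.1-fold higher number from compound 2 to compound 4 (0.05 log units; within the scatter) and a 1.6-fold higher number from compound 1 to compound 4 (0.20 log units; within the scatter). In this assay, a ring with a hetero atom on the double-bonded chain carbon therefore reads the same as the carbon-only groups. From the compounds shown here alone, whether an amine or a carboxylic acid here would move the number beyond the scatter stays open. No available measurement explains why these numbers stay so close.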